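Methoxy for (methylsulfonyl)methyl on compound 1

A few compounds are considered here, and "the series" means these few. Any claim that something is new, unique, unknown or untested is made for them only; others in the source may bear on it.

In a physicochemical assay for lipophilicity, using the shake flask method, in phosphate buffer, measured as octanol-water partition, with a stated time of 24 h, at pH 7.4, tested at 100 uM (a higher number here means a more lipophilic compound, a lower number a more polar compound), compound 1 (`Cc1cc(OCCCS(C)(=O)=O)cc(C)c1-c1cccc(COc2ccc(OCC(=O)O)c(F)c2)c1`) gives 1.81 and compound 2 (`Cc1cc(OCCCS(C)(=O)=O)ccc1-c1cccc(COc2ccc(OCC(=O)O)c(F)c2)c1`) gives 1.63 with the two lying within the scatter of each other, so these numbers set neither apart. Compound 3 (`COCCOc1cc(C)c(-c2cccc(COc3ccc(OCC(=O)O)c(F)c3)c2)c(C)c1`) departs from compound 1 by methoxy in place of (methylsulfonyl)methyl on a saturated chain carbon, two bonds along the chain from an oxygen on an aromatic ring and carries methoxy in place of (methylsulfonyl)methyl on a saturated chain carbon, two bonds along the chain from an oxygen on an aromatic ring. Among the measured compounds shown here, the only measured step (a number 0.18 log units lower from compound 1 to compound 2 (within the scatter)) is hydrogen in place of methyl on an aromatic carbon, a different change in a different place, and it does not gauge this exchange. Judged from the structural change alone, a step to a higher number in this assay is expected, beyond the scatter (a number 0.69 log units higher from compound 1 to compound 3 (beyond the scatter)). Compound 3 is estimated at 2.5 (expected range 2.1 to 3).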

Compound 3, distribution coefficient: 3.15
Compound 3: middle estimate off by 0.65 log units, on the low side, outside the stated range (above it).
By their numbers in this assay, from the lowest: compounds 2 and 1 (each within the scatter of the next); then compound 3.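

In this assay the exchange of 3-(methylsulfonyl)propoxy for 2-methoxyethoxy gives a number 1.34 log units higher from compound 1 to compound 3 (beyond the scatter) and so marks this chain end as a place where a single change separates two compounds. Among the compounds shown here, the earlier step, a number 0.18 log units lower from compound 1 to compound 2 (within the scatter), at an aromatic carbon, had set no two compounds apart. No available evidence explains why the number moves so far at this place.

Going by these compounds, it remains open whether the step follows the loss of (methylsulfonyl)methyl or the entry of methoxy, and how a hydroxyl, an amine or a longer chain ending in methoxy would read at this place. Also open, on these data alone, is whether the same exchange would give a step of similar size on compound 2, with hydrogen in place of the methyl.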